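From 1H-imidazol-2-yl to 1H-pyrazol-5-yl on a shared core

The compounds below may be only part of what the source reports. "The series", "measured", "known", "first", "only" and "open" are said of these compounds alone.

Compound 1 `O=C(Nc1ccc(-c2cccnc2)cc1)C1CCCN(Cc2ccc(F)c(F)c2)C1` measures 1060 nM
Compound 2 `O=C(Nc1ccc(-c2nccs2)cc1)C1CCCN(Cc2ccc(F)c(F)c2)C1` measures 800 nM
Compound 3 `O=C(Nc1ccc(-c2ncc[nH]2)cc1)C1CCCN(Cc2ccc(F)c(F)c2)C1` measures 8000 nM

All three numbers come from a functional assay on A-375 cells (Homo sapiens) for activation, with a stated time of 3 days (on this read-out higher numbers stand for an effect only at larger amounts of compound and lower numbers for an effect already at smaller amounts), and compound 3 has the highest of them, so it needs the most compound to show an effect. The next molecule, compound 4 `O=C(Nc1ccc(-c2ccn[nH]2)cc1)C1CCCN(Cc2ccc(F)c(F)c2)C1`, has the same atoms as compound 3, joined differently: 1H-pyrazol-5-yl in place of 1H-imidazol-2-yl on an aromatic carbon. In words, 1H-pyrazol-5-yl stands in place of 1H-imidazol-2-yl on an aromatic carbon.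

The measured steps all change this same group. Going to 1H-imidazol-2-yl gave a 7.5-fold higher number from compound 1 to compound 3 (0.88 log units; beyond the scatter) and also a 10-fold higher number from compound 2 to compound 3 (1.00 log units; beyond the scatter), while the other swap gave a 1.3-fold lower number from compound 1 to compound 2 (0.12 log units; within the scatter). For the measured compounds named here, no measured compound carries 1H-pyrazol-5-yl, so these steps offer only indirect guidance. Compound 1 at 1060 nM and compound 2 at 800 nM lie within the scatter of each other, which suggests that compound 3 may be the exception, and a partial return towards them is expected. The expected change is a 3.2-fold lower number from compound 3 to compound 4 (0.51 log units; beyond the scatter), a modest move to a lower number, though no real change remains possible. For compound 4 the estimate is 2500 nM, with an expected range from 700 nM to 9000 nM in this assay.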

Compound 4, half-maximal effective concentration: 580 nM
Beside the measured number, compound 4's estimate is 4.3-fold (0.63 log units) above it; the whole stated range lies above it.
By their numbers in this assay, from the lowest: compounds 4, 2 and 1 (each within the scatter of the next); then compound 3.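

Arrangement alone matters at this position: in this assay, 1H-pyrazol-5-yl in place of 1H-imidazol-2-yl gives a 14-fold lower number from compound 3 to compound 4 (1.14 log units; beyond the scatter) even though the two groups have the same atoms and the same counts of hydrogen-bond donors and acceptors. A donor on the five-membered ring therefore does not by itself go with a high number, as compound 3 and compound 4 each carry one and still sit far apart. Compound 4 also falls in with the other two compounds, with a 1.4-fold lower number from compound 2 to compound 4 (0.14 log units; within the scatter) from the 1,3-thiazol-2-yl group and a 1.8-fold lower number from compound 1 to compound 4 (0.26 log units; within the scatter) from the pyridin-3-yl group, so among these four compounds only the 1H-imidazol-2-yl group stands apart, and three different rings give numbers within the scatter of one another.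

On these data alone, whether a group of another kind at this place on the ring, such as an amine, a carboxylic acid or a simple methyl ester, could move the number clearly lower than these three remains open. Why the two arrangements of the same atoms differ so much also stays unanswered, as nothing available here speaks to a cause.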